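The compounds below may be only part of what the source reports. "The series", "measured", "known", "first", "only" and "open" are said of these compounds alone.

In a functional assay on MCF7 cells (Homo sapiens) for antiproliferative activity, read by MTT assay, with a stated time of 72 h (a lower number here means a stronger inhibitor, a higher number a weaker inhibitor), compound 1 `COc1ncc(-c2ccc3c(c2)N(c2ccccc2)C(=O)CO3)cc1NS(=O)(=O)c1ccc(F)cc1` gives 8870 nM as a measured number. In the same test, compound 2 `COc1ccc(N2C(=O)COc3ccc(-c4cnc5ccccc5c4)cc32)cc1` gives > 40000 nM as a limit of the assay and not a number. Compound 2 therefore stands at the limit of > 40000 nM in this assay, at which 1 of the 2 values shown sits, and offers no exact starting figure. Compound 3 `O=C1COc2ccc(-c3cnc4ccccc4c3)cc2N1c1ccccc1` differs from compound 2 in one place. The change hydrogen in place of methoxy on an aromatic carbon puts hydrogen in place of methoxy on an aromatic carbon, turning 4-methoxyphenyl into phenyl. Within the data shown here, no pair of measured compounds here shows this change on its own, so the data give no direct guide to its effect. Compounds 1 and 2 differ in more than this one place, and their two values cannot be assigned to any single group. The working expectation in this assay is therefore a small change with no favoured direction, and none beyond the usual scatter. The estimated step of a number no higher from compound 2 to compound 3 (the limit leaves the size open) is expected to be small, and the test may again return only a limit. For compound 3 the expected value is 40000 nM as a central estimate, with an expected range from 15000 nM to 80000 nM around it.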

Compound 3, half-maximal inhibitory concentration: > 40000 nM
Compound 3 gave a limit, no number (the forecaster's own chance of this, stated with the estimate: 65%); the middle value sits exactly at the limit.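

No step can be read from compound 2 to compound 3, since each gives only a limit of the assay and not a number: the limit of > 40000 nM in this assay, at which 2 of the 3 values shown sit. The compounds shown leave open whether the change from 4-methoxyphenyl to phenyl has any effect in this assay, and how large that effect might be.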